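A few compounds are considered here, and "the series" means these few. Any claim that something is new, unique, unknown or untested is made for them only; others in the source may bear on it.

Compound 1 `CC(C)[C@H](NC(=O)COc1cccc2ccccc12)C(=O)N[C@@H](CC(=O)O)C(=O)CSc1nccn1C` carries the shared core with a 1-methyl-1H-imidazol-2-yl group on the sulfur. In a functional assay on Jurkat cells (Homo sapiens) for inhibition (on this read-out lower numbers stand for stronger inhibition and higher numbers for weaker inhibition), compound 1 gives > 200000 nM, which is a limit of the assay and not a number. Compound 2 `CC(C)[C@H](NC(=O)COc1cccc2ccccc12)C(=O)N[C@@H](CC(=O)O)C(=O)CSc1nc(-c2ccccc2)c(-c2ccccc2)[nH]1` is a second analogue of the same core. In this assay compound 2 gives > 200000 nM, again a limit rather than a number. The whole measured picture is summarised by this: the limit of > 200000 nM in this assay, at which 2 of the 2 values shown sit. Among the compounds with values here, compound 1 thus stands at the limit, as does the only other measured compound, and no step between measured compounds can be stated.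

Compound 3 `Cc1nnc(SCC(=O)[C@H](CC(=O)O)NC(=O)[C@@H](NC(=O)COc2cccc3ccccc23)C(C)C)s1` is the next analogue: 5-methyl-1,3,4-thiadiazol-2-yl in place of 1-methyl-1H-imidazol-2-yl on a sulfur. Within the data shown here, no measured pair shows what a swap of this kind does on this core, so no direction can be read from the numbers. With compound 1 at the limit, the expectation for compound 3 is a step of a number no higher from compound 1 to compound 3 (the limit leaves the size open), meaning no shift beyond the scatter. Compound 3 is therefore estimated at 200000 nM, within 60000 nM to 600000 nM, and is expected most likely to come back as a limit once more.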

Compound 3, half-maximal inhibitory concentration: 190000 nM
Compound 3: the middle estimate sits 1.1-fold (0.02 log units) above what was measured; the range from low to high includes it.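

With 5-methyl-1,3,4-thiadiazol-2-yl in place of 1-methyl-1H-imidazol-2-yl on a sulfur, this assay shows an at least 1.0-fold lower number from compound 1 to compound 3 (0.02 log units; that floor lies within the scatter). Compound 3 is thus the only compound shown whose read-out on the shared core is a number rather than a limit, so this position now has one value that later changes can be set against, though this step does not establish a gain. Most of the series still sits at the edge of what the read-out can report: the limit of > 200000 nM in this assay, at which 2 of the 3 values shown sit.

Going by these compounds, the value of compound 1 is a limit and not a number, so the true size of the step remains open, and neither its direction beyond the scatter nor the share of the extra ring sulfur or the methyl placement in it can be read from this one pair. Also open, on these data alone, is what a benzyl group or a longer alkyl chain on the sulfur would do to the read-out on this core, and whether any group at this place can bring the series clearly clear of the limit.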